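Hydrogen in place of hydroxy on compound 2

This account rests on a few compounds, and the source may have more. Where it says the series, first, only, none or still open, it means among the compounds named here.

Compound 1 `C=Cc1cn([C@H]2C[C@H](O)[C@@H](CO)O2)c(=O)[nH]c1=O` gives 14200 nM
Compound 2 `CCC#Cc1cn([C@@H]2O[C@H](CO)[C@@H](O)[C@@H]2O)c(=O)[nH]c1=O` gives > 200000 nM

Within the data shown here, both values come from an ADME assay on L1210/0 cells (Mus musculus) for cytotoxicity, with a stated time of 48 h (a lower number here means a stronger inhibitor, a higher number a weaker inhibitor), and the one for compound 2 is a limit, not a number. Compound 2 therefore has the higher of the two figures, but no exact value. Compound 3 `CCC#Cc1cn([C@H]2C[C@H](O)[C@@H](CO)O2)c(=O)[nH]c1=O` differs from compound 2 by a single change hydrogen in place of hydroxy on a saturated ring carbon with hydrogen in place of hydroxy on a saturated ring carbon. Compound 1 also has hydrogen on that ring carbon and gives 14200 nM in this assay so a large fall in the number is expected, towards stronger inhibition. The expected change is an at least 4.0-fold lower number from compound 2 to compound 3 (0.60 log units; beyond the scatter) as an estimate only. For compound 3 the estimated value is 50000 nM (range 9000 nM to 200000 nM).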

Compound 3, half-maximal inhibitory concentration: > 200000 nM
Compound 3: a limit, no number; the forecaster's own chance of this, stated with the estimate: 25%; at least 4.0-fold (0.60 log units) between middle value and limit.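

In this assay the change from hydroxy to hydrogen on the saturated ring carbon cannot be read, because compound 2 and compound 3 both stop at a limit of the assay: the limit of > 200000 nM in this assay, at which 2 of the 3 values shown sit. With hydrogen on that ring carbon in both compounds, but-1-yn-1-yl in place of vinyl on the aromatic carbon gives an at least 14-fold higher number from compound 1 to compound 3 (1.14 log units; beyond the scatter). Hydrogen on that ring carbon therefore does not by itself bring a readable number.

Still open, on these data alone, is what hydroxy on that ring carbon does when vinyl sits on the aromatic carbon. Also open, as far as these compounds go, is how an amine or a longer chain on the aromatic carbon would read in this assay.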